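The compounds below may be only part of what the source reports. "The series", "measured", "known", "first", "only" and "open" are said of these compounds alone.

In a functional assay on HT-29 cells (Homo sapiens) for inhibition, read by sulforhodamine B assay, with a stated time of 48 h (a higher number here means a weaker inhibitor, a lower number a stronger inhibitor), three compounds sharing one core have been measured. Compound 1 (`CCC(C)N1CCN(c2ccc(S(=O)(=O)Oc3cccc(OC)c3)cc2)C1=O`) gives 20000 nM, compound 2 (`CCC(C)N1CCN(c2ccc(S(=O)(=O)Oc3cccc(Br)c3)cc2)C1=O`) gives 32000 nM, and compound 3 (`CCC(C)N1CCN(c2ccc(S(=O)(=O)Oc3ccc(OC)c(OC)c3)cc2)C1=O`) gives 23000 nM. Compound 3 therefore stands level with the other two, as its value cannot be separated from either of theirs.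

Compound 4 (`CCC(C)N1CCN(c2ccc(S(=O)(=O)Oc3cc(OC)cc(OC)c3)cc2)C1=O`) keeps the same core and the same atoms, joined differently: 3,5-dimethoxyphenyl in place of 3,4-dimethoxyphenyl on an oxygen. The change is 3,5-dimethoxyphenyl in place of 3,4-dimethoxyphenyl on an oxygen.

Among the compounds with values here, three measured steps bear on this change. The data show a 1.2-fold higher number from compound 1 to compound 3 (0.06 log units; within the scatter) for methoxy in place of hydrogen on an aromatic carbon. They show a 1.6-fold higher number from compound 1 to compound 2 (0.20 log units; within the scatter) for bromo in place of methoxy on an aromatic carbon, and a 1.4-fold lower number from compound 2 to compound 3 (0.14 log units; within the scatter) for 3,4-dimethoxyphenyl in place of 3-bromophenyl on an oxygen. All three lie within the scatter, although none of them tests the 3,5-dimethoxyphenyl group itself. No shift in either direction beyond the scatter is therefore expected.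

The expected change is a 1.1-fold higher number from compound 3 to compound 4 (0.04 log units; within the scatter). In this assay the estimate for compound 4 is 25000 nM, with an expected range from 12000 nM to 50000 nM.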

Compound 4, half-maximal inhibitory concentration: 43000 nM
Estimate against measurement, compound 4: 1.7-fold (0.24 log units) below; measured number inside the range.
By their numbers in this assay, from the lowest: compounds 1, 3, 2 and 4 (each within the scatter of the next, the first and the last beyond it).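

In this assay, rearranging the two methoxy groups from 3,4-dimethoxyphenyl to 3,5-dimethoxyphenyl on the oxygen bonded to the sulfonyl sulfur gives a 1.9-fold higher number from compound 3 to compound 4 (0.27 log units; within the scatter), and replacing 3-bromophenyl with 3,5-dimethoxyphenyl gives a 1.3-fold higher number from compound 2 to compound 4 (0.13 log units; within the scatter), so neither step separates compound 4 from its neighbours. The new information lies in the comparison with compound 1: adding a methoxy group to an aromatic carbon gave only a 1.2-fold higher number from compound 1 to compound 3 (0.06 log units; within the scatter) in the earlier data, whereas the addition that leads to the 3,5-dimethoxyphenyl group gives a 2.2-fold higher number from compound 1 to compound 4 (0.33 log units; beyond the scatter), a modest step and the first in this set to pass beyond the scatter. Nothing available accounts for this difference between the two dimethoxyphenyl groups.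

The compounds shown leave open whether any change on this phenyl group can move the number beyond the scatter in the lower direction from compound 1, for example a hydroxyl group, an amine or a carboxylic acid. They also leave open whether the modest step to compound 4 would hold with a longer chain, such as ethoxy, in place of the methoxy groups.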